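Two fluorines on the sulfonyl aryl: clearance of compound 4

The source may hold more compounds than are shown below. What is called first, only, known or untested is meant among the compounds shown, and "the series" means these compounds.

Measured compounds:
compound 1, `O=S(=O)(c1ccc(F)cc1)c1cnc2c(F)cccc2c1-c1cccc(Cl)c1`, 1.21 mL/min
compound 2, `COc1ccc(-c2c(S(=O)(=O)c3ccc(F)cc3)cnc3c(F)cccc23)cc1`, 2.41 mL/min
compound 3, `O=S(=O)(c1ccc(F)c(F)c1)c1cnc2c(F)cccc2c1-c1cccc(F)c1`, 1.28 mL/min

Three compounds of a shared core were run in an ADME assay on microsomes from liver (Homo sapiens) for metabolic stability, tested at 2.5 uM; on this read-out lower numbers stand for slow clearance and higher numbers for fast clearance. Compound 1 shows the lowest of the three numbers, but its nearest neighbour, compound 3, sits within the scatter of it, as does compound 2. Within the data shown here, the only single-place step among them, a 2.0-fold higher number from compound 1 to compound 2 (0.30 log units; within the scatter), lies within the scatter as well.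

Compound 4, `O=S(=O)(c1cc(F)cc(F)c1)c1cnc2c(F)cccc2c1-c1cccc(Cl)c1`, differs from compound 1 by 3,5-difluorophenyl in place of 4-fluorophenyl on a sulfonyl sulfur. Among the measured compounds shown here, none of the measured steps touches this place: the step from compound 1 to compound 2 changes the aryl on an aromatic carbon, and compound 3 differs from compound 1 in two places at once, so its value can only be set beside that of compound 1, where the two lie within the scatter. For the measured compounds named here, with no step in this assay bearing on the change, the account expects no movement beyond the scatter, a 1.1-fold higher number from compound 1 to compound 4 (0.03 log units; within the scatter). Compound 4 is estimated at 1.3 mL/min, within 0.65 mL/min to 2.6 mL/min.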

Compound 4, intrinsic clearance in a liver preparation (reported as CLH), per the amount of preparation that the assay uses: 0.64 mL/min
Compound 4: the middle estimate sits 2.0-fold (0.31 log units) above what was measured, outside the stated range (below it).
By their numbers in this assay, from the lowest: compounds 4, 1, 3 and 2 (each within the scatter of the next, the first and the last beyond it).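

Among these compounds, this is the first step at the sulfonyl sulfur that can be read in one place: in this assay, 3,5-difluorophenyl in place of 4-fluorophenyl gives a 1.9-fold lower number from compound 1 to compound 4 (0.28 log units; within the scatter) and so stays inside the scatter. At this position, then, the second fluorine and the altered fluorine pattern on the aryl leave the clearance number without a change that can be told from repeat variation, at least on the background of compound 1. No measurement at hand offers a reason for the size of this step.

The compounds shown leave open whether a group of another kind on the sulfonyl sulfur, such as a pyridine or an aryl bearing an amine or a carboxylic acid, would move the number beyond the scatter. They also leave open whether the same exchange would read alike with 4-methoxyphenyl on the aromatic carbon.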